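Aryl groups in place of acetyl on the core

A few compounds are considered here, and "the series" means these few. Any claim that something is new, unique, unknown or untested is made for them only; others in the source may bear on it.

Measured so far:
compound 1 `CC(=O)N(C)c1ccc2[nH]c(-c3n[nH]c4ccccc34)cc2n1` — > 50000 nM
compound 2 `COc1cccc(C(=O)N(C)c2ccc3[nH]c(-c4n[nH]c5ccccc45)cc3n2)c1` — 14900 nM

In a functional assay on A549 cells (Homo sapiens) for antiproliferative activity, read by MTT assay, with a stated time of 72 h (on this read-out lower numbers stand for stronger inhibition and higher numbers for weaker inhibition), compound 1 gives > 50000 nM, which is a limit of the assay rather than a number (the limit of > 50000 nM in this assay, at which 1 of the 2 values shown sits). In this assay compound 2 gives 14900 nM. Within the data shown here, the only step that bears on the question is an at least 3.3-fold lower number from compound 1 to compound 2 (0.52 log units; beyond the scatter), in which an aromatic ring entered on the carbonyl carbon. Compound 3 `CN(c1ccc2[nH]c(-c3n[nH]c4ccccc34)cc2n1)S(=O)(=O)c1ccc(Cl)cc1` differs from compound 1 as follows: (4-chlorophenyl)sulfonyl in place of acetyl on a nitrogen on an aromatic ring. Since an aromatic ring enters again, a lower number is expected, with a step of about an at least 4.1-fold lower number from compound 1 to compound 3 (0.61 log units; beyond the scatter). For compound 3 the estimate is 12000 nM, ranging from 3000 nM to 50000 nM.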

Compound 3, half-maximal inhibitory concentration: 18200 nM
Estimate against measurement, compound 3: 1.5-fold (0.18 log units) below; the measured number falls inside the stated range.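

In this assay the change at this nitrogen need not keep the carbonyl: (4-chlorophenyl)sulfonyl in place of acetyl gives an at least 2.7-fold lower number from compound 1 to compound 3 (0.43 log units; beyond the scatter). The sulfonyl and carbonyl aryl groups are not told apart here, with a 1.2-fold higher number from compound 2 to compound 3 (0.09 log units; within the scatter). The true size of the first step stays open, as compound 1 stands at a limit and not at a number: the limit of > 50000 nM in this assay, at which 1 of the 3 values shown sits.

Nothing shown separates the contribution of the chlorine from that of the aromatic ring. Also open, going by these compounds, is whether an amine or a carboxylic acid on that ring would move the number further.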